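The compounds below may be only part of what the source reports. "The series", "measured", "known", "first", "only" and "open" are said of these compounds alone.

Measured in a functional assay on MCF7 cells (Homo sapiens) for cytotoxicity, read by MTT assay, with a stated time of 24 h; on this read-out higher numbers stand for weaker inhibition and lower numbers for stronger inhibition:

- Compound 1 `O=C1/C(=C/c2ccccc2F)CN(C(=S)SCc2cn(Cc3ccccc3Cl)nn2)C/C1=C\c1ccccc1F`: 78700 nM
- Compound 2 `O=C1/C(=C/c2ccccc2F)CN(C(=S)SCc2cn(Cc3ccccc3F)nn2)C/C1=C\c1ccccc1F`: 51600 nM
- Compound 3 `O=C1/C(=C/c2ccccc2F)CN(Cc2cn(Cc3ccc(F)cc3)nn2)C/C1=C\c1ccccc1F`: 6000 nM

Compound 2, at 51600 nM, lies within the scatter of compound 1 and holds the second highest of the three numbers. Compound 3 stands well apart at 6000 nM, but it differs from compound 2 in more than one place and offers no direct guide here.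

The next compound to be tested is compound 4 `O=C1/C(=C/c2ccccc2F)CN(C(=S)SCc2cn(Cc3cccc(Cl)c3)nn2)C/C1=C\c1ccccc1F`. The change is 3-chlorophenyl in place of 2-fluorophenyl on a saturated chain carbon bound to an aromatic nitrogen.

Among the compounds with values here, only one measured step bears on this change. That step, fluoro in place of chloro on an aromatic carbon, is a 1.5-fold lower number from compound 1 to compound 2 (0.18 log units; within the scatter). Within the data shown here, no measured pair shows what moving the halogen does, so this evidence is limited. No shift beyond the scatter is therefore expected in this assay, in either direction.

The estimated change is a 1.2-fold higher number from compound 2 to compound 4 (0.07 log units; within the scatter). For compound 4 the expected value is 60000 nM, with an estimated range of 25000 nM to 130000 nM.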

Compound 4, half-maximal inhibitory concentration: > 100000 nM
Compound 4 gave a limit, no number; the forecaster's own chance of this, stated with the estimate: 8%; middle value at least 1.6-fold (0.22 log units) from the limit.
By their numbers in this assay, from the lowest: compound 3; then compounds 2 and 1 (each within the scatter of the next). At a limit, above all of these: compound 4.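

Compound 4 gave no number in this assay, only a limit: the limit of > 100000 nM in this assay, at which 1 of the 4 values shown sits. At this place, on a saturated chain carbon bound to an aromatic nitrogen, 3-chlorophenyl in place of 2-chlorophenyl gives an at least 1.2-fold higher number from compound 1 to compound 4 (0.10 log units; that floor lies within the scatter), and 3-chlorophenyl in place of 2-fluorophenyl gives an at least 1.9-fold higher number from compound 2 to compound 4 (0.28 log units; that floor lies within the scatter). Unlike the earlier swap of chloro for fluoro, these steps include a move of the halogen on the ring, and neither gives a lower number, yet with both floors within the scatter a shift beyond it is neither shown nor ruled out.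

The compounds shown leave open the actual value of compound 4. They also leave open whether 4-chlorophenyl, or a benzyl ring carrying an amine or a carboxylic acid, would give a measurable number at this place.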